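The source may hold more compounds than are shown below. What is called first, only, known or untested is meant among the compounds shown, and "the series" means these compounds.

Of the compounds shown here, two built on one shared core have been measured so far. Compound 1, `Cc1ccc(Nc2nc(N)nc(COc3ccc4c(C)cc(=O)oc4c3)n2)cc1`, and compound 2, `CCCc1cc(=O)oc2cc(OCc3nc(N)nc(Nc4ccc(C)cc4)n3)ccc12`, were both tested in an assay on COS-7 cells for agonist activity at Free fatty acid receptor 1 (Homo sapiens), read by scintillation counting and inositol phosphate accumulation, with a stated time of 90 min; a higher number here means that more compound is needed for the effect, a lower number that less compound is needed. Compound 1 gives 1790 nM. Compound 2 gives 2900 nM, and the step of a 1.6-fold higher number from compound 1 to compound 2 (0.21 log units; within the scatter) stays within the usual scatter of repeated measurements, so the two compounds stand level with each other as far as this measurement can tell.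

Compound 3, `Cc1ccc(Nc2nc(N)nc(COc3ccc4c(C(F)F)cc(=O)oc4c3)n2)cc1`, has not yet been tested. It differs from compound 2 in a single place: difluoromethyl in place of propyl on an aromatic carbon. Among the measured compounds shown here, the only measured step, a 1.6-fold higher number from compound 1 to compound 2 (0.21 log units; within the scatter), altered the chain at this same place and produced nothing beyond the scatter. For the measured compounds named here, nothing in the data shows how a difluoromethyl in place of a propyl behaves here, so the measured step is the only guide.

The expectation is therefore a step of a 1.3-fold lower number from compound 2 to compound 3 (0.12 log units; within the scatter) that stays within the scatter. Compound 3 is estimated at 2200 nM in this assay. The range expected for compound 3 runs from 800 nM to 6000 nM.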

Compound 3, half-maximal effective concentration: 3180 nM
Beside the measured number, compound 3's estimate is 1.4-fold (0.16 log units) below it; low and high end bracket the measured number.
By their numbers in this assay, from the lowest: compounds 1, 2 and 3 (each within the scatter of the next).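

In this assay, putting difluoromethyl in place of propyl on this aromatic carbon gives a 1.1-fold higher number from compound 2 to compound 3 (0.04 log units; within the scatter), and putting it in place of methyl gives a 1.8-fold higher number from compound 1 to compound 3 (0.25 log units; within the scatter). The earlier compounds shown here showed only that two plain carbon chains at this place stand level; these steps add a group that carries fluorine and has the same count of heavy atoms as propyl, and it stands level with both chains, so within these three compounds this assay does not separate the groups at this position. Nothing available here explains why these three groups stand level.

The compounds shown leave open whether a group of a different kind at this same place, such as an amine, a carboxylic acid or a longer chain, would also stay level with these three or would move the number beyond the scatter. They also leave open whether this level result would hold if another part of the shared core were different.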